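From 2-methoxyphenyl to (4-methoxyphenyl)amino on the shared core

The source may report more compounds than this note shows. Statements on the series, on what has been measured and on what is new or still open speak of the compounds shown alone.

In a functional assay on A549 cells (Homo sapiens) for antiproliferative activity, read by MTT assay, with a stated time of 72 h (on this read-out higher numbers stand for weaker inhibition and lower numbers for stronger inhibition), compound 1 `COc1cc(C(=O)c2sc3ccccc3c2-c2ccccc2)cc(OC)c1OC` gives 5000 nM and compound 2 `COc1ccc(-c2c(C(=O)c3cc(OC)c(OC)c(OC)c3)sc3ccccc23)cc1` gives 4400 nM, with a 1.1-fold lower number from compound 1 to compound 2 (0.06 log units; within the scatter). Compound 3 `COc1ccccc1-c1c(C(=O)c2cc(OC)c(OC)c(OC)c2)sc2ccccc12` has only a limit, > 10000 nM.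

Compound 4 `COc1ccc(Nc2c(C(=O)c3cc(OC)c(OC)c(OC)c3)sc3ccccc23)cc1` carries (4-methoxyphenyl)amino in place of 2-methoxyphenyl on an aromatic carbon. The closest guide is an at least 2.2-fold higher number from compound 2 to compound 3 (0.35 log units; beyond the scatter), which points to the 4-methoxyphenyl group as the better of the two. an at least 2.0-fold higher number from compound 1 to compound 3 (0.30 log units; that floor lies within the scatter) has a floor within the scatter. For the measured compounds named here, no measured step covers the amino link, so the expectation is loose. A return towards compound 2 at 4400 nM is expected in this assay, a modest drop: the expected change is an at least 3.3-fold lower number from compound 3 to compound 4 (0.52 log units; beyond the scatter). The estimate for compound 4 is 3000 nM, with an expected range of 500 nM to 10000 nM.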

Compound 4, half-maximal inhibitory concentration: 9300 nM
For compound 4 the middle estimate is 3.1-fold (0.49 log units) below the measured one, within the range that was stated.
By their numbers in this assay, from the lowest: compounds 2, 1 and 4 (each within the scatter of the next, the first and the last beyond it). At a limit, above all of these: compound 3.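

In this assay the amino link does not hold the level of the directly attached ring: a 2.1-fold higher number from compound 2 to compound 4 (0.33 log units; beyond the scatter). Set against phenyl, the same position gives a 1.9-fold higher number from compound 1 to compound 4 (0.27 log units; within the scatter), so no order stands between those two compounds. The step that ends at compound 4 from a limit, an at least 1.0-fold lower number from compound 3 to compound 4 (0.03 log units; that floor lies within the scatter), fixes no order: the limit of > 10000 nM in this assay, at which 1 of the 4 values shown sits.

Open, from the compounds shown here alone, is whether the loss in compound 4 follows the amine link itself or the 4-methoxyphenyl group on it. A plain phenylamino group or an ether link at this position would separate the two.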